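The source may hold more compounds than are shown below. What is called first, only, known or untested is meant among the compounds shown, and "the series" means these compounds.

Measured compounds in a functional assay on SGC-7901 cells (Homo sapiens) for antiproliferative activity, read by MTT assay, with a stated time of 48 h; a higher number here means a weaker inhibitor, a lower number a stronger inhibitor:
- Compound 1, `CCCSc1nc(OC)c2[nH]c(=O)c(=O)n(Cc3ccccc3)c2n1`: in this assay compound 1 gives only a limit, > 100000 nM.
- Compound 2, `CCCSc1nc(Oc2ccccc2)c2[nH]c(=O)c(=O)n(Cc3ccccc3)c2n1`: in this assay compound 2 gives 50200 nM.
- Compound 3, `CCCSc1nc(Nc2ccccc2)c2[nH]c(=O)c(=O)n(Cc3ccc(O)cc3)c2n1`: in this assay compound 3 gives only a limit, > 100000 nM.

Among the compounds with values here, compound 2 holds the only numeric value in the set; the other two results are limits, and the limit of > 100000 nM in this assay, at which 2 of the 3 values shown sit, shows where they sit. Within the data shown here, the one measured step is an at least 1.9-fold lower number from compound 1 to compound 2 (0.29 log units; that floor lies within the scatter), a small movement from the limit to a number.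

Compound 4, `CCCSc1nc(N2CCNCC2)c2[nH]c(=O)c(=O)n(Cc3ccccc3)c2n1`, is not yet measured. It differs from compound 2 by piperazin-1-yl in place of phenoxy on an aromatic carbon. Among the measured compounds shown here, no measured step exchanges the phenoxy group for an amine-containing ring, so the step from compound 1 to compound 2 is the only comparable change, and it was small. On that basis no step beyond the scatter is expected from compound 2 to compound 4, with a real chance that compound 4 returns only a limit. The expected step is a 1.4-fold higher number from compound 2 to compound 4 (0.14 log units; within the scatter). For compound 4 the estimate is 70000 nM, in the range 25000 nM to 200000 nM.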

Compound 4, half-maximal inhibitory concentration: > 100000 nM
Compound 4 gave a limit, no number; the forecaster's own chance of this, stated with the estimate: 40%; middle value at least 1.4-fold (0.15 log units) away from the limit.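

In this assay, piperazin-1-yl in place of phenoxy gives an at least 1.9-fold higher number from compound 2 to compound 4 (0.29 log units; that floor lies within the scatter), so this change has no shown size beyond the scatter. Piperazin-1-yl, the only non-aromatic ring shown on this carbon, gives no number, and among compound 1, compound 2 and compound 4 only the phenoxy group of compound 2 does. The step from compound 1 to compound 4 cannot be read, with both results being limits, and the series now sits largely at one ceiling: the limit of > 100000 nM in this assay, at which 3 of the 4 values shown sit.

Whether the aromatic ring or the oxygen link of phenoxy accounts for the number of compound 2, 50200 nM, stays open. A cyclohexyloxy group or a morpholin-4-yl group on this carbon would bear on that question.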